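Chlorophenyl in place of methylphenyl: expectation for compound 4

The compounds below may be only part of what the source reports. "The series", "measured", "known", "first", "only" and "open" are said of these compounds alone.

The series starts from compound 1 `Oc1ccccc1CNc1ccccc1`, which in a functional assay on Jurkat cells (Homo sapiens) for activation, with a stated time of 24 h (on this read-out lower numbers stand for an effect already at smaller amounts and higher numbers for an effect only at larger amounts of compound), comes out as "not active" (no number reported). Compound 2 `Oc1ccccc1CNc1ccc(-c2cccc(F)c2)cc1` gives 2020 nM, and compound 3 `Cc1cccc(-c2ccc(NCc3ccccc3O)cc2)c1` gives 9190 nM. Compound 3 therefore holds the highest of the two reported numbers, with a 4.5-fold higher number from compound 2 to compound 3 (0.66 log units; beyond the scatter) separating it from compound 2. Compound 4 `Oc1ccccc1CNc1ccc(-c2ccccc2Cl)cc1` differs from compound 3 by 2-chlorophenyl in place of 3-methylphenyl on an aromatic carbon. Within the data shown here, only the step from compound 2 to compound 3 bears on this change: a halogen-bearing ring went with a lower number than the methyl-bearing one. Since the entering group is not the same as that of compound 2, a smaller move is expected. For compound 4 a step of a 2.6-fold lower number from compound 3 to compound 4 (0.42 log units; beyond the scatter) is expected. Compound 4 is thus estimated at 3500 nM, between 900 nM and 14000 nM.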

Compound 4, half-maximal effective concentration: "not active" (no number reported)
Nothing numeric was reported for compound 4; the estimate stays without a comparison.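

Among these compounds, compound 4 gives "not active" (no number reported) and so no step from compound 3 can be read. No measured evidence bears on this result. The compounds shown leave open whether the chlorine or its position on the ring goes with the absent number.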